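A few compounds are considered here, and "the series" means these few. Any claim that something is new, unique, unknown or untested is made for them only; others in the source may bear on it.

Of the compounds shown here, three from a single series have been tested in a functional assay on EKVX cells (Homo sapiens) for inhibition, read by sulforhodamine B assay, with a stated time of 48 h; a lower number here means a stronger inhibitor of growth, a higher number a weaker inhibitor of growth. Compound 1 `COc1ccc2[nH]c(-c3ccccc3)c(C=C(C#N)C#N)c2c1` gives 4100 nM. Compound 2 `COc1ccc(-c2[nH]c3ccc(OC)cc3c2/C=C(\C#N)S(=O)(=O)c2ccccc2)cc1` gives 3300 nM, and compound 3 `CC(=O)/C(=C\c1c(-c2ccccc2)[nH]c2ccccc12)S(=O)(=O)c1ccccc1` gives 3300 nM. Compound 3 thus stands level with compound 2, and its gap to compound 1 falls within the scatter, so the three numbers are not separable. Compound 4 `N#C/C(=C\c1c(-c2ccccc2)[nH]c2ccccc12)S(=O)(=O)c1ccccc1` differs from compound 3 by cyano in place of acetyl on a double-bonded chain carbon bound to a double-bonded chain carbon and a sulfonyl sulfur. No change of this kind has been measured within the series; as the three known values sit so close, the step is expected to be none beyond the scatter in this assay. Compound 4 is therefore estimated at 3300 nM, with a range from 1500 nM to 7500 nM, amounting to no change at the digits printed from compound 3 to compound 4 (within the scatter).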

Compound 4, concentration for 50% growth inhibition: 6200 nM
Estimate against measurement, compound 4: 1.9-fold (0.27 log units) below; measured number inside the range.
By their numbers in this assay, from the lowest: compounds 2, 3, 1 and 4 (each within the scatter of the next).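

On the double-bonded chain carbon bound to a double-bonded chain carbon and a sulfonyl sulfur, cyano in place of acetyl gives the first step read at this position in this assay, a 1.9-fold higher number from compound 3 to compound 4 (0.27 log units; within the scatter). This position therefore accepts either group without a change that stands clear of the scatter. No measurement here accounts for the step.

Going by these compounds, whether a carboxylic acid or an amine at this position would give a number beyond the scatter stays open. So does whether the same exchange gives a similar step on the core of compound 2.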